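A few compounds are considered here, and "the series" means these few. Any claim that something is new, unique, unknown or untested is made for them only; others in the source may bear on it.

In a functional assay on the whole organism (strain Sprague-Dawley) for inhibition, with Rattus norvegicus as the target, with a stated time of 10 min (a lower number here means that less compound is needed, a higher number that more compound is needed for the effect), three compounds sharing one core have been measured. Compound 1 (`CCOC(=O)c1cnc(-c2ccccc2OCC)[nH]c1=O`) gives 2 mg/kg here, compound 2 (`CCOC(=O)c1cnc(-c2cc(OC)ccc2OCC)[nH]c1=O`) gives 0.3 mg/kg here, and compound 3 (`CCOC(=O)c1cnc(-c2cc(S(N)(=O)=O)ccc2OCC)[nH]c1=O`) gives 50 mg/kg as the highest number of the three. Compound 4 (`CCOC(=O)c1cnc(-c2cc(S(=O)(=O)N(C)C)ccc2OCC)[nH]c1=O`) differs from compound 3 in one place (dimethylamino in place of amino on a sulfonyl sulfur): dimethylamino in place of amino on a sulfonyl sulfur, which turns sulfamoyl into dimethylsulfamoyl.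

Three measured steps show how much this part of the molecule matters. Sulfamoyl in place of hydrogen gave a 25-fold higher number from compound 1 to compound 3 (1.40 log units; beyond the scatter) as a large step. Sulfamoyl in place of methoxy gave a 170-fold higher number from compound 2 to compound 3 (2.22 log units; beyond the scatter) as another large step. Methoxy in place of hydrogen gave a 6.7-fold lower number from compound 1 to compound 2 (0.82 log units; beyond the scatter) as a modest step. Among the compounds with values here, none of them alters the amino on the sulfonyl sulfur, so the change has no direct precedent. A modest step to a lower number is expected in this assay with wide uncertainty, recovering part of a 25-fold higher number from compound 1 to compound 3 (1.40 log units; beyond the scatter) at most. The expected step is a 4.2-fold lower number from compound 3 to compound 4 (0.62 log units; beyond the scatter) as a rough estimate. For compound 4 the estimated dose is 12 mg/kg with an expected range from 2 mg/kg to 60 mg/kg for now.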

Compound 4, dose for 50% inhibition: 50 mg/kg
Compound 4: middle estimate off by 4.2-fold (0.62 log units), on the low side; measured number inside the range.
By their numbers in this assay, from the lowest: compound 2; then compound 1; then compounds 3 and 4 (each within the scatter of the next).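

In this assay, dimethylamino in place of amino on the sulfonyl sulfur gives no change at the digits printed from compound 3 to compound 4 (within the scatter), so losing the hydrogen-bond donor counted on amino goes with no readable difference. The large cost of a sulfonyl group on this aromatic carbon remains: dimethylsulfamoyl shows a 25-fold higher number from compound 1 to compound 4 (1.40 log units; beyond the scatter) against hydrogen and a 170-fold higher number from compound 2 to compound 4 (2.22 log units; beyond the scatter) against methoxy, steps of the same printed size as those for sulfamoyl. Nothing available here explains why the change on the sulfur leaves the dose as it is.

From the compounds shown here alone, whether a longer chain or a morpholine ring on the sulfonyl sulfur would also leave the dose unchanged stays open. Within the data shown here, also open is how a carboxylic acid or an amine on that aromatic carbon would compare with methoxy, the only group here giving a lower number than hydrogen.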